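The source may hold more compounds than are shown below. What is called first, only, known or untested is meant among the compounds shown, and "the series" means these compounds.

In an assay on HEK293 cells for inhibition of protein kinase C zeta type (Homo sapiens), read by 33P incorporation, with a stated time of 40 min, tested at 20 uM, in the presence of a further agent that is not named here (on this read-out higher numbers stand for more inhibition at the one concentration tested (going by the name of the read-out) and lower numbers for less inhibition), compound 1 `COc1ccc(C2=NN(c3ccc(Cl)cc3)C(c3ccc(Cl)cc3)C2)cc1` gives 23%, the lowest of the three numbers in hand. Compound 2 `COc1ccc(C2=NN(c3ccc(Cl)cc3)C(c3ccc(Cl)cc3)C2)c(OC)c1` gives 28.6%, a step of a number 5.6 percentage points higher from compound 1 to compound 2 (within the scatter). Compound 3 `COc1ccc(C2=NN(c3ccc(Cl)cc3)C(c3cccc(Cl)c3)C2)cc1` gives 39%, a step of a number 16 percentage points higher from compound 1 to compound 3 (beyond the scatter). Compound 4 `COc1ccc(C2=NN(c3cccc(Cl)c3)C(c3ccc(Cl)cc3)C2)cc1` differs from compound 1 by 3-chlorophenyl in place of 4-chlorophenyl on an amine nitrogen in a ring. For the measured compounds named here, no measured step changes the group on the ring nitrogen; the step from compound 1 to compound 3 moves the chlorine of the other chlorophenyl group in the same way, on a ring carbon, and is modest. He therefore expects at most a modest rise in this assay, a number 9 percentage points higher from compound 1 to compound 4 (within the scatter), and estimates for compound 4 a value of 32%, between 18% and 48%.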

Compound 4, a percentage reported as inhibition, at one concentration (the size of the read-out at that concentration, not a potency): 30.8%
Compound 4: the middle estimate sits 1.2 percentage points above what was measured; the range from low to high includes it.
By their numbers in this assay, from the lowest: compounds 1, 2, 4 and 3 (each within the scatter of the next, the first and the last beyond it).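

In this assay, 3-chlorophenyl in place of 4-chlorophenyl on the amine nitrogen in a ring gives a number 7.8 percentage points higher from compound 1 to compound 4 (within the scatter), so at this position the change cannot be told from the scatter. The same exchange on the saturated ring carbon gives a number 16 percentage points higher from compound 1 to compound 3 (beyond the scatter), so the two places do not read alike in this small set. Nothing measured here offers a reason for that difference. On these data alone, it remains open how a carboxylic acid or a dimethylamino group on the phenyl ring at that nitrogen would read, and whether both chlorine moves together would add up in one compound.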